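This account rests on a few compounds, and the source may have more. Where it says the series, first, only, none or still open, it means among the compounds named here.

Three compounds built on one shared core were tested in a functional assay on MCF7 cells (Homo sapiens) for antiproliferative activity, read by MTT assay, with a stated time of 72 h; a lower number here means a stronger inhibitor, a higher number a weaker inhibitor. Compound 1 `CC(C)(C)c1cn(C[C@H](O)[C@H]2OC(=O)C(OCc3ccccc3)=C2OCc2ccccc2)nn1` carries a tert-butyl group and gives 730 nM. Compound 2 `O=C1O[C@H]([C@@H](O)Cn2cc(-c3cccc(O)c3)nn2)C(OCc2ccccc2)=C1OCc1ccccc1` carries a 3-hydroxyphenyl group in its place and gives 51800 nM. Compound 3 `O=C1O[C@H]([C@@H](O)Cn2cc(-c3cc(F)cc(F)c3)nn2)C(OCc2ccccc2)=C1OCc1ccccc1` carries a 3,5-difluorophenyl group and gives 27700 nM. Among these three numbers compound 3 lies far from compound 1 and close to compound 2: the step of a 38-fold higher number from compound 1 to compound 3 (1.58 log units; beyond the scatter) is large, whereas a 1.9-fold lower number from compound 2 to compound 3 (0.27 log units; within the scatter) stays within the scatter. The remaining step, a 71-fold higher number from compound 1 to compound 2 (1.85 log units; beyond the scatter), is also large, so among the measured compounds each aromatic group at this position gives a much higher number than tert-butyl.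

Compound 4 `O=C1O[C@H]([C@@H](O)Cn2cc(CNS(=O)(=O)c3ccc(F)cc3)nn2)C(OCc2ccccc2)=C1OCc1ccccc1` alters this same position once more: (((4-fluorophenyl)sulfonyl)amino)methyl in place of 3,5-difluorophenyl on an aromatic carbon. For the measured compounds named here, no measured step swaps an aromatic group for a group of this kind, so the two large steps away from compound 1 and the flat step between compound 2 and compound 3 are the only guide, and neither points to a return toward the number of compound 1. The number for compound 4 in this assay is therefore expected to stay close to that of compound 3, with a 1.1-fold higher number from compound 3 to compound 4 (0.03 log units; within the scatter) expected to lie within the scatter. The estimate for compound 4 is 30000 nM, with a range from 8000 nM to 120000 nM.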

Compound 4, half-maximal inhibitory concentration: 26800 nM
Beside the measured number, compound 4's estimate is 1.1-fold (0.05 log units) above it, within the range that was stated.
By their numbers in this assay, from the lowest: compound 1; then compounds 4, 3 and 2 (each within the scatter of the next).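

In this assay, for the compounds shown here, this position tolerates a far larger change than the earlier compounds tested. The group (((4-fluorophenyl)sulfonyl)amino)methyl adds sulfur, nitrogen, oxygen, a hydrogen-bond donor and hydrogen-bond acceptors that 3,5-difluorophenyl lacks, yet a 1.0-fold lower number from compound 3 to compound 4 (0.01 log units; within the scatter) and a 1.9-fold lower number from compound 2 to compound 4 (0.29 log units; within the scatter) both leave the number within the scatter. The gap to tert-butyl also persists, with a 37-fold higher number from compound 1 to compound 4 (1.56 log units; beyond the scatter) being large, so all three groups that hold a six-membered aromatic ring now sit far from compound 1, whether or not a sulfonyl and amino unit comes with that ring, and no available evidence gives a reason for this.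

Still open, from the compounds shown here alone, is whether the lower number of compound 1 belongs to tert-butyl alone or extends to other groups without an aromatic ring, such as methyl, cyclohexyl or a longer alkyl chain. Equally open, going by these compounds, is how an aminomethyl group, a carboxylic acid or a methylsulfonylaminomethyl group, which keeps the sulfonyl and amino unit but has no fluorophenyl ring, would compare with these four compounds.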